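Trifluoromethoxy for trifluoromethyl on the aryl thioether

The source may report more compounds than this note shows. Statements on the series, on what has been measured and on what is new or still open speak of the compounds shown alone.

Compound 1 `CC(O)(CSc1ccc(C(F)(F)F)cc1)C(=O)Nc1ccc(S(F)(F)(F)(F)F)cc1` is the reference point of this set. In a functional assay on LNCaP cells (Homo sapiens) for antiproliferative activity, read by propidium iodide staining, with a stated time of 96 h (on this read-out lower numbers stand for stronger inhibition and higher numbers for weaker inhibition), compound 1 gives 17000 nM. Compound 2 `CC(O)(CSc1ccc(OC(F)(F)F)cc1)C(=O)Nc1ccc(S(F)(F)(F)(F)F)cc1` carries the same core with the change (trifluoromethoxy in place of trifluoromethyl on an aromatic carbon); in this assay compound 2 gives 16100 nM, and the step is a 1.1-fold lower number from compound 1 to compound 2 (0.02 log units; within the scatter), so the two values are not distinguishable here.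

Compound 3 `CC(O)(CSc1ccccc1C(F)(F)F)C(=O)Nc1cccc(S(F)(F)(F)(F)F)c1` is built from the same atoms as compound 1, joined differently; the difference between the two cores is not broken down here. In this assay compound 3 gives 12300 nM, which lies within the scatter of both compound 1 and compound 2.

Compound 4 `CC(O)(CSc1ccccc1OC(F)(F)F)C(=O)Nc1cccc(S(F)(F)(F)(F)F)c1` is not yet measured. It differs from compound 3 by trifluoromethoxy in place of trifluoromethyl on an aromatic carbon. This is the same kind of change as that from compound 1 to compound 2, not the same change: in compound 2 the entering group sits para to a large group, whereas in compound 4 it sits ortho to a large group.

For compound 4 the step from compound 3 is expected to be a 1.1-fold lower number from compound 3 to compound 4 (0.03 log units; within the scatter), essentially flat, because a 1.1-fold lower number from compound 1 to compound 2 (0.02 log units; within the scatter). The different surroundings of the place of change add some uncertainty, so the range is set wide. Compound 4 is estimated at 11500 nM in this assay, with a range from 5500 nM to 24000 nM.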

Compound 4, half-maximal inhibitory concentration: 10000 nM
Estimate against measurement, compound 4: 1.2-fold (0.06 log units) above, within the range that was stated.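

In this assay the exchange of trifluoromethyl for trifluoromethoxy, here on an aromatic carbon ortho to a large group, gives a 1.2-fold lower number from compound 3 to compound 4 (0.09 log units; within the scatter) and so reads as flat on this second core as well. Set side by side, the two steps cannot be told apart, so within these two pairs the change carries from one core to the other without a detectable difference: the same change on two cores in this assay, a 1.1-fold lower number (0.02 log units; within the scatter) from compound 1 to compound 2 and a 1.2-fold lower number (0.09 log units; within the scatter) from compound 3 to compound 4, 1.2-fold (0.07 log units) apart, within the scatter of two such steps. Going by these compounds alone, this shows only that the exchange is neutral on these two cores at this level of inhibition; it does not show that the exchange would stay neutral on another core or at another place on the ring, nor can two flat steps reveal how strongly the surroundings of the group could alter its effect on compounds with much lower numbers.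

The compounds shown carry only trifluoromethyl or trifluoromethoxy on the aryl thioether, so it remains open whether a nitrile, a methoxy group or a chlorine in that place would give a step beyond the scatter. Also open, on these data alone, is what follows when the thioether sulfur becomes a sulfone or the hydroxyl gives way to an amine, on either core.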